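The source may hold more compounds than are shown below. What is called first, only, known or untested is meant among the compounds shown, and "the series" means these compounds.

In a functional assay on HepG2 cells (Homo sapiens) for inhibition, read by scintillation counting, with a stated time of 2 h (on this read-out lower numbers stand for stronger inhibition and higher numbers for weaker inhibition), compound 1 `CCCCC(=O)N1CCC(N2CCN(C(=O)c3c(NC(=O)NCC)sc4ccccc34)CC2)CC1` gives "not determined" (no result reported), compound 2 `CCNC(=O)Nc1sc2ccccc2c1C(=O)N1CCN(C2CCN(C(=O)OC(C)C)CC2)CC1` gives 208 nM and compound 3 `CCNC(=O)Nc1sc2ccccc2c1C(=O)N1CCN(C2CCN(C(=O)OC3CCCCC3)CC2)CC1` gives 635 nM, the higher of the two numbers available. The unmeasured compound 4 `CCNC(=O)Nc1sc2ccccc2c1C(=O)N1CCN(C2CCN(C(=O)OC(C)(C)C(F)(F)F)CC2)CC1` carries 1-methyl-1-(trifluoromethyl)ethyl in place of cyclohexyl on an oxygen next to a carbonyl group. Among the measured compounds shown here, only one measured step bears on this place, a 3.1-fold higher number from compound 2 to compound 3 (0.48 log units; beyond the scatter), with cyclohexyl in place of isopropyl. The entering group has no ring, like the isopropyl of compound 2 at 208 nM, so a modest move back toward that lower number is expected. The expected change is a 2.1-fold lower number from compound 3 to compound 4 (0.33 log units; beyond the scatter). In this assay compound 4 is estimated at 300 nM, with an expected range from 110 nM to 850 nM.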

Compound 4, half-maximal inhibitory concentration: 81 nM
Compound 4: the middle estimate sits 3.7-fold (0.57 log units) above what was measured; measured number below the stated range.
By their numbers in this assay, from the lowest: compound 4; then compound 2; then compound 3.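

In this assay the change to 1-methyl-1-(trifluoromethyl)ethyl gives a 7.8-fold lower number from compound 3 to compound 4 (0.89 log units; beyond the scatter) and trifluoromethyl in place of hydrogen gives a 2.6-fold lower number from compound 2 to compound 4 (0.41 log units; beyond the scatter) so losing the cyclohexyl ring does more than return the number to that of compound 2. Among the groups shown on this oxygen, the lowest number now belongs to the one carrying fluorine. Nothing available explains this gain. As far as these compounds go, a plain tert-butyl group at this place would separate the contribution of the trifluoromethyl from that of the added carbon branching, and how an amine in this chain would behave remains open.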